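Swapping a para bromo for methoxy on the thromboxane synthase series

The source may report more compounds than this note shows. Statements on the series, on what has been measured and on what is new or still open speak of the compounds shown alone.

Of the compounds shown here, two of one core have been measured in an assay (Equus caballus) for inhibition of Thromboxane-A synthase (Homo sapiens), using microsomes; on this read-out lower numbers stand for stronger inhibition and higher numbers for weaker inhibition. Compound 1 `O=C(O)CCCC/C=C(/c1ccc(F)cc1)c1cccnc1` gives 83 nM. Compound 2 `O=C(O)CCCC/C=C(/c1ccc(Br)cc1)c1cccnc1` gives 82 nM. Within the data shown here, the single measured step, a 1.0-fold lower number from compound 1 to compound 2 (0.01 log units; within the scatter), lies within the scatter, so the two numbers cannot be told apart; compound 2 stands level with compound 1 rather than apart from it.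

Compound 3 `COc1ccc(/C(=C/CCCCC(=O)O)c2cccnc2)cc1` is not yet measured. It differs from compound 2 in one place: methoxy in place of bromo on an aromatic carbon. Among the measured compounds shown here, the only step that bears on this change is the one from fluoro to bromo at the same position, which moved the number by a 1.0-fold lower number from compound 1 to compound 2 (0.01 log units; within the scatter), within the scatter. That step shows the position accepting two different groups without a change in this assay, but it says nothing directly about methoxy, which is not a halogen and brings one hydrogen-bond acceptor. For the measured compounds named here, with no closer precedent, the estimated step is a 1.1-fold higher number from compound 2 to compound 3 (0.04 log units; within the scatter), expected to stay within the scatter. Compound 3 is therefore expected to give about 90 nM in this assay, with a likely range from 40 nM to 200 nM.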

Compound 3, half-maximal inhibitory concentration: 80 nM
Compound 3: middle estimate off by 1.1-fold (0.05 log units), on the high side, and the stated range covers the measured number.
By their numbers in this assay, from the lowest: compounds 3, 2 and 1 (each within the scatter of the next).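

Among these compounds, until this result the position had carried only halogens, and methoxy is the first group of another kind there: in this assay methoxy in place of bromo gives a 1.0-fold lower number from compound 2 to compound 3 (0.01 log units; within the scatter) and methoxy in place of fluoro gives a 1.0-fold lower number from compound 1 to compound 3 (0.02 log units; within the scatter) so neither step separates the compounds. Methoxy has two heavy atoms where bromo has one, and it has a hydrogen-bond acceptor where bromo has none, yet at this aromatic carbon, para to a large group, the three compounds cannot be told apart. No supporting measurement is available to explain why the numbers stay level.

An amine, a hydroxyl, a carboxylic acid or a longer chain such as butoxy at this same aromatic carbon could still behave differently, so the tolerance seen here is shown only for fluoro, bromo and methoxy. Among the compounds shown here, the three compounds also leave open whether the same holds with the rest of the shared core changed, since every step so far alters this one position only.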